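A few compounds are considered here, and "the series" means these few. Any claim that something is new, unique, unknown or untested is made for them only; others in the source may bear on it.

Of the compounds shown here, three sharing one core have been measured in an assay on LtK cells with ATP-sensitive inward rectifier potassium channel 11 (Homo sapiens) as the target; on this read-out higher numbers stand for an effect only at larger amounts of compound and lower numbers for an effect already at smaller amounts. Compound 1 `CCCC(=O)Nc1c(C(O)(C(F)(F)F)C(F)(F)F)ccc2ccccc12` carries a propyl group on the carbonyl carbon and gives 131 nM. Compound 2 `O=C(Nc1c(C(O)(C(F)(F)F)C(F)(F)F)ccc2ccccc12)C1CCCC1` carries a cyclopentyl group there and gives 495 nM. Compound 3 `N#Cc1cccc(C(=O)Nc2c(C(O)(C(F)(F)F)C(F)(F)F)ccc3ccccc23)c1` carries a 3-cyanophenyl group and gives 12 nM, the lowest of the three numbers; its steps to both others lie beyond the scatter, so on these numbers compound 3 is the most potent. The step of a 3.8-fold higher number from compound 1 to compound 2 (0.58 log units; beyond the scatter) shows that swapping one saturated group for another moved the number only modestly, whereas an 11-fold lower number from compound 1 to compound 3 (1.04 log units; beyond the scatter) and a 41-fold lower number from compound 2 to compound 3 (1.62 log units; beyond the scatter) show that an aromatic ring in place of a saturated group brought large drops.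

Compound 4 `O=C(Nc1c(C(O)(C(F)(F)F)C(F)(F)F)ccc2ccccc12)c1ccco1` has not yet been measured. It differs from compound 3 in one place: furan-2-yl in place of 3-cyanophenyl on a carbonyl carbon. An aromatic ring and one acceptor remain on the carbonyl carbon, but the ring is now five-membered and the nitrile is gone. Within the data shown here, no measured step compares two aromatic groups, and nothing here shows what the nitrile alone contributes, so the two large steps only suggest that an aromatic group here is favourable. Compound 4 is therefore expected to give a modestly higher number than compound 3, a step of a 2.9-fold higher number from compound 3 to compound 4 (0.46 log units; beyond the scatter), with an estimated 35 nM and a range from 10 nM to 120 nM.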

Compound 4, half-maximal effective concentration: 9 nM
Compound 4: the middle estimate sits 3.9-fold (0.59 log units) above what was measured; the whole stated range lies above it.
By their numbers in this assay, from the lowest: compounds 4 and 3 (each within the scatter of the next); then compound 1; then compound 2.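

In this assay, among these compounds, the step to furan-2-yl gives the first comparison of two aromatic groups on the carbonyl carbon (a 1.3-fold lower number from compound 3 to compound 4 (0.12 log units; within the scatter)), so compounds 3 and 4 cannot be told apart and the nitrile is not required for a number this low. The large steps seen with 3-cyanophenyl also recur with this different ring (a 15-fold lower number from compound 1 to compound 4 (1.16 log units; beyond the scatter) and a 55-fold lower number from compound 2 to compound 4 (1.74 log units; beyond the scatter)), so the advantage over propyl and cyclopentyl now holds for both aromatic groups shown, a six-membered ring of carbon only and a five-membered ring containing oxygen. No measurement available here explains why these two different rings give such similar numbers. The compounds shown leave open whether an aromatic ring alone is enough, since a plain phenyl group or a thiophen-2-yl group would show what remains without the nitrile or the furan oxygen. They also leave open how much the rest of the structure contributes, since the shared core stays unchanged in all four compounds.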